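The source may report more compounds than this note shows. Statements on the series, on what has been measured and on what is new or still open speak of the compounds shown alone.

This account follows two compounds that share one core and another compound that has not yet been measured. Compound 2 `CN1CCN(c2ccc(NC(=N)c3cc4c(-c5ccccc5)n[nH]c4cn3)cc2)CC1` carries a phenyl group on the core and a bare ring nitrogen; in a functional assay on HT-1080 cells (Homo sapiens) for cytotoxicity, read by MTT assay, with a stated time of 72 h (a lower number here means a stronger inhibitor, a higher number a weaker inhibitor), compound 2 gives 11400 nM, the higher of the two numbers in hand. Compound 1 `COc1ccc(Cn2ncc3cc(C(=N)Nc4ccc(N5CCN(C)CC5)cc4)ncc32)cc1` is the nearest comparison: in this assay compound 1 gives 5300 nM, and the gap to compound 2 lies beyond the scatter, though these two structures differ in more than one place, so no single change can be credited for it. Compound 3 `COc1ccc(Cn2nc(-c3ccccc3)c3cc(C(=N)Nc4ccc(N5CCN(C)CC5)cc4)ncc32)cc1` is built from compound 2 by one change: 4-methoxybenzyl in place of hydrogen on an aromatic nitrogen. Among the measured compounds shown here, no measured pair isolates this change; the only hint is that compound 1, which carries the 4-methoxybenzyl group, gives the lower number. A modest step toward a lower number is expected, a 1.8-fold lower number from compound 2 to compound 3 (0.24 log units; within the scatter), of a size close to the scatter. Compound 3 is therefore estimated at 6500 nM in this assay, with a range from 2500 nM to 16000 nM.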

Compound 3, half-maximal inhibitory concentration: 1090 nM
The estimate for compound 3 lay 6.0-fold (0.78 log units) above the measured number; the measured number lies below the stated range.
By their numbers in this assay, from the lowest: compound 3; then compound 1; then compound 2.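

In this assay, the 4-methoxybenzyl group on the aromatic nitrogen now has a measured pair of its own: with the phenyl group on the ring atom two ring bonds away, this change gives a 10-fold lower number from compound 2 to compound 3 (1.02 log units; beyond the scatter), so a substituent at this nitrogen goes with a large fall in the number. The two groups also work together in this series rather than against each other, since phenyl in place of hydrogen on the aromatic carbon gives a 4.9-fold lower number from compound 1 to compound 3 (0.69 log units; beyond the scatter), and compound 3, which carries both, has the lowest number of the three compounds. Nothing in hand explains either step.

With only the 4-methoxybenzyl group shown on this nitrogen, it remains open whether the methoxy group matters at all, or whether a plain benzyl, a methyl or a longer chain ending in an amine would give a similar number. It is also open whether the size of this step depends on the phenyl group, as the compounds shown hold no pair that reads the 4-methoxybenzyl change without it.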